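This account rests on a few compounds, and the source may have more. Where it says the series, first, only, none or still open, it means among the compounds named here.

Measured so far:
- Compound 1 `O=[N+]([O-])c1cc(CSc2nnc(-c3ccc(Cl)cc3)n2Cc2ccccc2)cc([N+](=O)[O-])c1`: > 30000 nM
- Compound 2 `O=[N+]([O-])c1cc(CSc2nnc(-c3ccc(Cl)cc3)n2Cc2ccccc2)cc(C(F)(F)F)c1`: > 30000 nM
- Compound 3 `COc1ccc(CSc2nnc(-c3cc([N+](=O)[O-])cc([N+](=O)[O-])c3)n2Cc2ccccc2)cc1`: > 30000 nM

In an ADME assay on A-431 cells (Homo sapiens) for cytotoxicity, with a stated time of 48 h (a lower number here means a stronger inhibitor, a higher number a weaker inhibitor), compound 1 reaches only a limit of the assay. Compound 2 likewise gives only a limit in this assay. Compound 3 too stops at a limit. The change from compound 1 to compound 2 is trifluoromethyl in place of nitro on an aromatic carbon and its step, a step that the two limits leave unreadable from compound 1 to compound 2, cannot be read because both ends sit at the limit of > 30000 nM in this assay, at which 3 of the 3 values shown sit. Compound 4 `COc1ccc(CSc2nnc(-c3cc([N+](=O)[O-])cc(C(F)(F)F)c3)n2Cc2ccccc2)cc1` is not yet measured; it differs from compound 3 by trifluoromethyl in place of nitro on an aromatic carbon, the same change. How the cores of compound 1 and compound 3 differ is not broken down here. Compound 4 is expected to stay at the limit, a step that the limit leaves unreadable from compound 3 to compound 4, because compound 3 already sits at the limit of > 30000 nM in this assay, at which 3 of the 3 values shown sit. The estimate for compound 4 is 40000 nM, between 15000 nM and 100000 nM.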

Compound 4, half-maximal inhibitory concentration: > 30000 nM
Compound 4 gave a limit, no number (the forecaster's own chance of this, stated with the estimate: 85%); the middle value is on the limit's open side.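

No new step can be read between compound 3 and compound 4, because both give only a limit, not a number: the limit of > 30000 nM in this assay, at which 4 of the 4 values shown sit.

The compounds shown leave open how strong any of them is, and whether trifluoromethyl in place of nitro changes that at all.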